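A few compounds are considered here, and "the series" means these few. Any claim that something is new, unique, unknown or untested is made for them only; others in the source may bear on it.

Measured compounds:
compound 1 `COc1cc(C(=O)c2sc(-c3ccc(I)cc3)cc2N)cc(OC)c1OC`: 420 nM
compound 2 `COc1cc(C(=O)c2sc(-c3ccc(Cl)c(Cl)c3)cc2N)cc(OC)c1OC`: 400 nM
compound 3 `COc1cc(C(=O)c2sc(-c3ccc(C)cc3)cc2N)cc(OC)c1OC`: 16 nM

In a functional assay on FM3A cells (Mus musculus) for antiproliferative activity (a lower number here means a stronger inhibitor, a higher number a weaker inhibitor), compound 1 gives the highest of the three numbers; compound 2 sits within the scatter of it, a 1.1-fold lower number from compound 1 to compound 2 (0.02 log units; within the scatter), while compound 3 lies far off, a 26-fold lower number from compound 1 to compound 3 (1.42 log units; beyond the scatter). Compound 4 `COc1cc(C(=O)c2sc(-c3cccs3)cc2N)cc(OC)c1OC` differs from compound 1 in one place: thiophen-2-yl in place of 4-iodophenyl on an aromatic carbon. Among the measured compounds shown here, no measured step exchanges the whole ring for a thiophen-2-yl, so none bears directly on it. The steps at hand show that changing the group on this carbon can leave the number unchanged, as in a 1.1-fold lower number from compound 1 to compound 2 (0.02 log units; within the scatter), or lower it greatly, as in a 25-fold lower number from compound 2 to compound 3 (1.40 log units; beyond the scatter). Compound 4 is therefore expected to land between those outcomes, a 2.8-fold lower number from compound 1 to compound 4 (0.45 log units; beyond the scatter), with an estimated 150 nM and a range of 30 nM to 800 nM.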

Compound 4, half-maximal inhibitory concentration: 1.7 nM
The estimate for compound 4 lay 88-fold (1.95 log units) above the measured number; the measured number lies below the stated range.
By their numbers in this assay, from the lowest: compound 4; then compound 3; then compounds 2 and 1 (each within the scatter of the next).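

In this assay, among the compounds shown here, the earlier compounds changed only the substituents on a phenyl ring at this carbon, whereas replacing that ring with thiophen-2-yl gives a 250-fold lower number from compound 1 to compound 4 (2.39 log units; beyond the scatter) and a 240-fold lower number from compound 2 to compound 4 (2.37 log units; beyond the scatter). The change also goes beyond the 4-methylphenyl group, with a 9.4-fold lower number from compound 3 to compound 4 (0.97 log units; beyond the scatter), so that group does not mark the lowest number reachable at this position. Nothing measured here accounts for this gain.

The compounds shown leave open whether the gain belongs to the ring sulfur or to the five-membered ring, which a furan-2-yl or thiophen-3-yl group would test. Also open, on these data alone, is whether a methyl group or an amine on the thiophen-2-yl ring would keep it.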